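Swapping a methylthiophene for a chlorophenyl

This account rests on a few compounds, and the source may have more. Where it says the series, first, only, none or still open, it means among the compounds named here.

Values in a functional assay on DU-145 cells (Homo sapiens) for inhibition, read by trypan blue exclusion, with a stated time of 96 h; on this read-out higher numbers stand for weaker inhibition of growth and lower numbers for stronger inhibition of growth:
Compound 1 `Cc1ccc(S(=O)(=O)/C(=C/c2sccc2C)C(=O)c2ccc(Cl)cc2)cc1`: 10000 nM
Compound 2 `COc1ccccc1/C=C(\C(=O)c1ccc(Cl)cc1)S(=O)(=O)c1ccc(C)cc1`: 1000 nM
Compound 3 `Cc1ccc(S(=O)(=O)/C(=C/c2ccc(C)s2)C(=O)c2ccc(Cl)cc2)cc1`: 50000 nM

Of these three, compound 3 has the highest number, so it holds back growth the least. Compound 4 `Cc1ccc(S(=O)(=O)/C(=C/c2ccc(Cl)cc2)C(=O)c2ccc(Cl)cc2)cc1` changes one group of compound 3: 4-chlorophenyl in place of 5-methylthiophen-2-yl on a double-bonded chain carbon bound to a double-bonded chain carbon. The closest guide is the 2-methoxyphenyl group, the only six-membered aromatic ring measured at this place. It stands behind a large step, a 50-fold higher number from compound 2 to compound 3 (1.70 log units; beyond the scatter), whereas the two thiophenes differ by a modest one, a 5.0-fold higher number from compound 1 to compound 3 (0.70 log units; beyond the scatter). Among the measured compounds shown here, no measured compound shows what a 4-chlorophenyl does here, so a sizeable drop in this assay is expected only tentatively. The expected change is a 17-fold lower number from compound 3 to compound 4 (1.22 log units; beyond the scatter). For compound 4 the estimate is 3000 nM, with an expected range of 500 nM to 20000 nM.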

Compound 4, concentration for 50% growth inhibition: 1000 nM
For compound 4 the middle estimate is 3.0-fold (0.48 log units) above the measured one; measured number inside the range.
By their numbers in this assay, from the lowest: compounds 2 and 4 (each within the scatter of the next); then compound 1; then compound 3.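

The 4-chlorophenyl group gives a 50-fold lower number from compound 3 to compound 4 (1.70 log units; beyond the scatter) and a 10-fold lower number from compound 1 to compound 4 (1.00 log units; beyond the scatter) when it replaces a thiophene, so the lower numbers at this place are not confined to the 2-methoxyphenyl group. Against that group it shows no change at the digits printed from compound 2 to compound 4 (within the scatter) and so matches it, although the two six-membered aromatic rings carry different substituents. Nothing available explains the gap between these rings and the thiophenes.

Still open, from the compounds shown here alone, is what a plain phenyl ring without any substituent would give at this place. A pyridine ring or a 4-aminophenyl group also remains untested among these compounds.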